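Replacing Phenyl with Methyl on the Shared Core

This account rests on a few compounds, and the source may have more. Where it says the series, first, only, none or still open, it means among the compounds named here.

Among the compounds with values here, in an ADME assay on L6 cells (Rattus norvegicus) for cytotoxicity, read by resazurin assay, with a stated time of 70 h (on this read-out higher numbers stand for weaker inhibition and lower numbers for stronger inhibition), compound 3 `Cc1ccccc1C(=O)Nc1cc(-c2ccccc2)ccn1` gives 70000 nM, the lowest of the three numbers measured so far. Compound 1 `Cc1ccccc1C(=O)Nc1cc(Cl)ccn1` gives 224000 nM and compound 2 `Cc1ccnc(NC(=O)c2ccc(F)c(F)c2C)c1` gives 223000 nM, two values that agree within the scatter. Compound 4 `Cc1ccnc(NC(=O)c2ccccc2C)c1` has methyl in place of phenyl on an aromatic carbon, opposite the ring nitrogen: methyl in place of phenyl on an aromatic carbon. Within the data shown here, the one measured step that bears directly on this change is a 3.2-fold lower number from compound 1 to compound 3 (0.51 log units; beyond the scatter), which put phenyl in place of chloro at that carbon and lies modestly beyond the scatter. Compound 4 gives up that phenyl, so a step of similar size in the opposite direction is expected in this assay. Compound 2 shares the methyl but also carries fluoro groups, so it offers only indirect support with its 223000 nM. The expected change is a 2.9-fold higher number from compound 3 to compound 4 (0.46 log units; beyond the scatter), a modest move to a higher number. Compound 4 is estimated at 200000 nM, with an expected range from 110000 nM to 340000 nM.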

Compound 4, half-maximal inhibitory concentration: 146000 nM
For compound 4 the middle estimate is 1.4-fold (0.14 log units) above the measured one, within the range that was stated.
By their numbers in this assay, from the lowest: compound 3; then compounds 4, 2 and 1 (each within the scatter of the next).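

In this assay the change at this carbon, opposite the ring nitrogen, gives a 2.1-fold higher number from compound 3 to compound 4 (0.32 log units; beyond the scatter) when methyl replaces phenyl, so the lower number of compound 3 now stands out against methyl as well as against chloro. Methyl in place of chloro gives a 1.5-fold lower number from compound 1 to compound 4 (0.19 log units; within the scatter) and this step lies within the scatter, so methyl and chloro cannot be told apart at this carbon in these compounds. Nothing given here explains either step, and no measurement points to a cause.

The compounds shown leave open whether an amine or a methoxy group at this carbon would read like phenyl or like methyl and chloro. They also leave open whether a pyridine ring or a benzyl group in this place would keep the lower number seen with phenyl.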